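Swapping the Thiophene for a Chlorophenyl Ring

A few compounds are considered here, and "the series" means these few. Any claim that something is new, unique, unknown or untested is made for them only; others in the source may bear on it.

Compound 3 `C=C(Br)C(=O)Nc1cccc(-c2cn3nc(-c4cccs4)sc3n2)c1` is the strongest inhibitor among the three compounds measured in a functional assay on HeLa cells (Homo sapiens) for inhibition, read by cell counting, with a stated time of 4 days; on this read-out higher numbers stand for weaker inhibition and lower numbers for stronger inhibition: compound 3 gives 670 nM. Compound 2 `C=C(Br)C(=O)Nc1cccc(-c2cn3nc(-c4ccc(C)cc4)sc3n2)c1` gives 2000 nM, and compound 1 `C=C(Br)C(=O)Nc1cccc(-c2cn3nc(Cc4ccccc4)sc3n2)c1` gives 4500 nM. Both steps toward compound 3 lie beyond the scatter: a 3.0-fold lower number from compound 2 to compound 3 (0.47 log units; beyond the scatter) and a 6.7-fold lower number from compound 1 to compound 3 (0.83 log units; beyond the scatter). Compound 4 `C=C(Br)C(=O)Nc1cccc(-c2cn3nc(-c4ccc(Cl)cc4)sc3n2)c1` has not yet been measured. It differs from compound 3 in one place: 4-chlorophenyl in place of thiophen-2-yl on an aromatic carbon. The measured step that bears most directly on this change is a 3.0-fold lower number from compound 2 to compound 3 (0.47 log units; beyond the scatter), as compound 4, like compound 2, carries a six-membered carbon ring with one substituent in place of the thiophen-2-yl group. That step is expected to run roughly in reverse, so compound 4 is expected to show weaker inhibition than compound 3, a step of about a 2.2-fold higher number from compound 3 to compound 4 (0.35 log units; beyond the scatter). Compound 4 is therefore estimated at 1500 nM, with a range from 600 nM to 4000 nM. Among the compounds with values here, no measured pair shows a chlorine in place of a methyl group, so the exact size of the step remains uncertain.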

Compound 4, half-maximal inhibitory concentration: 3000 nM
Estimate against measurement, compound 4: 2.0-fold (0.30 log units) below; the range from low to high includes it.
By their numbers in this assay, from the lowest: compound 3; then compounds 2, 4 and 1 (each within the scatter of the next, the first and the last beyond it).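

In this assay, the step to 4-chlorophenyl (a 4.5-fold higher number from compound 3 to compound 4 (0.65 log units; beyond the scatter)) gives a second case, after 4-methylphenyl, in which a six-membered carbon ring at this position gives weaker inhibition than the thiophen-2-yl group, so compound 3 now stands clear of all three other compounds. Chloro in place of methyl (a 1.5-fold higher number from compound 2 to compound 4 (0.18 log units; within the scatter)) and 4-chlorophenyl in place of benzyl (a 1.5-fold lower number from compound 1 to compound 4 (0.18 log units; within the scatter)) both stay within the scatter, so neither change can be told apart from repeat-measurement noise. Nothing available explains the gap between the thiophen-2-yl group and the six-membered rings. On these data alone, it remains open whether a furan-2-yl ring, or a thiophene carrying a methyl group, would match compound 3. The compounds shown also leave open how a 4-aminophenyl or 4-carboxyphenyl ring would compare with 4-chlorophenyl.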